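The compounds below may be only part of what the source reports. "The series", "measured", "known", "first", "only" and "open" are said of these compounds alone.

Measured compounds:
Compound 1, `NCc1ccc2oc(=O)c(C(=O)Oc3cccc(Cl)c3)cc2c1`, 86.6%
Compound 2, `CC(=O)NCc1ccc2oc(=O)c(C(=O)Oc3ccccc3)cc2c1`, 63.5%

In a functional assay on HT-1080 cells (Homo sapiens), read by transwell migration, with a stated time of 24 h, tested at 1 uM (on this read-out higher numbers stand for a weaker effect at the one concentration tested and lower numbers for a stronger effect), compound 2 gives 63.5%, the lowest of the two numbers shown. Its nearest neighbour is compound 1, which in this assay gives 86.6%, a number higher by a margin beyond the scatter; the two compounds differ in more than one place, so only their two values can be compared. The unmeasured compound 3, `CC(=O)NCc1ccc2oc(=O)c(C(=O)Oc3cccc(Cl)c3)cc2c1`, is reached from compound 2 by a single change: chloro in place of hydrogen on an aromatic carbon. Among the compounds with values here, no measured pair isolates this change, so its size in this assay is unknown. Within the data shown here, for compound 3 a small step is expected, a number 4.5 percentage points higher from compound 2 to compound 3 (within the scatter), not beyond the scatter, since the only other compound carrying the chloro group, compound 1, also differs elsewhere. Compound 3 is therefore estimated at 68%, with a range from 48% to 88%.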

Compound 3, a percentage reported as activity, at one concentration (the size of the read-out at that concentration, not a potency): 36.6%
For compound 3 the middle estimate is 31.4 percentage points above the measured one; measured number below the stated range.
By their numbers in this assay, from the lowest: compound 3; then compound 2; then compound 1.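

In this assay, the change from phenoxy to 3-chlorophenoxy on the acetylated amine gives a number 26.9 percentage points lower from compound 2 to compound 3 (beyond the scatter) and so shows that this aromatic carbon is not silent: chloro in place of hydrogen moves the read-out towards a stronger effect. With the 3-chlorophenoxy group held fixed, acetyl in place of hydrogen on the amine nitrogen gives a number 50 percentage points lower from compound 1 to compound 3 (beyond the scatter) and so shows that the amine nitrogen also matters, a point the two earlier compounds could not separate. Nothing at hand gives a reason for either step.

The compounds shown leave open whether chloro has a similar effect when the amine is free. They also leave open how fluoro or methoxy at this place, or a propionyl group on the nitrogen, would compare.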